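The source may report more compounds than this note shows. Statements on the series, on what has been measured and on what is new or still open speak of the compounds shown alone.

Working notes on the series. Compound 1 `COc1ccc(C2N=C(SCc3ccccc3)NC(C)=C2C(=O)Nc2ccc(F)cc2)cc1OC` gives 6.2% in a functional assay on the whole organism (artery, strain albino) with Rattus norvegicus as the target, with a stated time of 60 min, at a dose of 10 mg/kg by the oral route; on this read-out lower numbers stand for less inhibition and higher numbers for more inhibition at the one dose given (going by the name of the read-out). Compound 2 `COc1ccc(C2N=C(SCc3ccccc3Cl)NC(C)=C2C(=O)Nc2ccc(F)cc2)cc1OC` differs from compound 1 by chloro in place of hydrogen on an aromatic carbon; in this assay compound 2 gives 11.8%, and the step is a number 5.6 percentage points higher from compound 1 to compound 2 (within the scatter). Compound 3 `CC1=C(C(=O)Nc2ccc([N+](=O)[O-])cc2)C(c2ccc(Br)cc2)N=C(SCc2ccccc2)N1` is built on a core whose difference from the core of compound 1 is not broken down here; in this assay compound 3 gives 8.2%. Compound 4 `CC1=C(C(=O)Nc2ccc([N+](=O)[O-])cc2)C(c2ccc(Br)cc2)N=C(SCc2ccccc2Cl)N1` has not been measured; it differs from compound 3 by chloro in place of hydrogen on an aromatic carbon, the same change and at the same place as that from compound 1 to compound 2. Given a number 5.6 percentage points higher from compound 1 to compound 2 (within the scatter), the step of a number 4.8 percentage points higher from compound 3 to compound 4 (within the scatter) is expected, because compound 3 stands at 8.2%. Compound 4 is therefore estimated at 13%, with an expected range from 3% to 23%.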

Compound 4, a percentage reported as inhibition, in the whole organism at one dose (the size of the read-out at that dose, not a potency): 6.7%
For compound 4 the middle estimate is 6.3 percentage points above the measured one; the measured number falls inside the stated range.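

In this assay, the change from benzyl to 2-chlorobenzyl gives a number 1.5 percentage points lower from compound 3 to compound 4 (within the scatter). Set beside the earlier step, the two cores do not separate: the same change on two cores in this assay, a number 5.6 percentage points higher (within the scatter) from compound 1 to compound 2 and a number 1.5 percentage points lower (within the scatter) from compound 3 to compound 4, 7.1 percentage points apart, within the scatter of two such steps

This pair of steps gives no sign that the core alters the effect of the change, but it does not show that the effect carries over from one core to the other, as neither step stands clear of the scatter. The compounds shown leave open how an amine or a carboxylic acid in place of the chloro would read, and how a longer chain in place of the benzyl would read. Also open is how any of these compounds would read at another dose.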